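This account rests on a few compounds, and the source may have more. Where it says the series, first, only, none or still open, it means among the compounds named here.

Compound 1 `N#C/C(=C/c1ccc(Cl)cc1)C(=O)c1ccc[nH]1`: 38000 nM
Compound 2 `N#C/C(=C/c1ccc([N+](=O)[O-])cc1)C(=O)c1ccc[nH]1`: < 10000 nM

Both values come from a functional assay on NCI-H460 cells (Homo sapiens) for cytotoxicity, read by MTT assay, with a stated time of 72 h; a higher number here means a weaker inhibitor of growth, a lower number a stronger inhibitor of growth. For compound 2 the value < 10000 nM is a limit and not a number, as the limit of < 10000 nM in this assay, at which 1 of the 2 values shown sits, records. Compound 3 `N#C/C(=C/c1ccc(O)cc1)C(=O)c1ccc[nH]1` carries hydroxy in place of nitro on an aromatic carbon, with hydroxy in place of nitro on an aromatic carbon as the counted difference. Going by the values given here, only one measured step bears on this place: an at least 3.8-fold lower number from compound 1 to compound 2 (0.57 log units; beyond the scatter), with nitro in place of chloro. A move away from nitro is therefore expected to give a modest rise in the number, of about that size. The expected step is an at least 2.0-fold higher number from compound 2 to compound 3 (0.30 log units; that floor lies within the scatter). For compound 3 the estimate is 20000 nM, with an expected range of 6000 nM to 60000 nM.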

Compound 3, concentration for 50% growth inhibition: < 10000 nM
Compound 3: no number, only a limit; the forecaster's own chance of this, stated with the estimate: 25%; middle value at least 2.0-fold (0.30 log units) from the limit.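

Exchanging chloro for hydroxy, para to a large group, gives an at least 3.8-fold lower number from compound 1 to compound 3 (0.57 log units; beyond the scatter) in this assay, so among the compounds shown the fall from the chloro compound is not confined to nitro. The step from compound 2 to compound 3 cannot be read, because both values are limits and not numbers: the limit of < 10000 nM in this assay, at which 2 of the 3 values shown sit.

Going by these compounds, how far the true values of compound 2 and compound 3 lie past that limit stays open. Also open, on these data alone, is whether an amine or a carboxylic acid at this place would reach the same limit.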